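The compounds below may be only part of what the source reports. "The series", "measured", "known", "first", "only" and "open" are said of these compounds alone.

Measured compounds and their values:

Compound 1, `Cc1ccc(-n2nncc2CN2C(=O)C3(C(C#N)=C(N)Oc4c3c3nc5ccccc5nc3c3ccccc43)c3ccccc32)cc1Cl`. In a functional assay on MCF7 cells (Homo sapiens) for antiproliferative activity, read by MTT assay, with a stated time of 48 h (a lower number here means a stronger inhibitor, a higher number a weaker inhibitor), compound 1 gives > 50000 nM, which is a limit of the assay and not a number.
Compound 2, `Cc1ccc(Cl)cc1-n1nncc1CN1C(=O)C2(C(C#N)=C(N)Oc3c2c2nc4ccccc4nc2c2ccccc32)c2ccccc21`. In this assay compound 2 gives > 50000 nM, again a limit.
Compound 3, `Cc1cccc(-n2nncc2CN2C(=O)C3(C(C#N)=C(N)Oc4c(N)cc5nc6ccccc6nc5c43)c3ccccc32)c1`. In this assay compound 3 gives > 50000 nM, also a limit.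

Compound 3 therefore stands nowhere in particular on the numbers shown: it sits at the limit of > 50000 nM in this assay, at which 3 of the 3 values shown sit, and the other two compounds sit there with it. The step from compound 3 to compound 4, `N#CC1=C(N)Oc2c(N)cc3nc4ccccc4nc3c2C12C(=O)N(Cc1cnnn1-c1ccccc1Cl)c1ccccc12`, is 2-chlorophenyl in place of 3-methylphenyl on an aromatic nitrogen. Going by the values given here, the only measured step that touches the group on the aromatic nitrogen of the triazole is a step that the two limits leave unreadable from compound 1 to compound 2, and since both of its ends are limits it gives no size at all. Among the compounds with values here, no measured step resolves any change, so there is no basis to expect a step beyond the scatter in this assay in either direction. Compound 4 is therefore expected to remain at the limit as well, with an estimate of 60000 nM and a range from 20000 nM to 200000 nM. The estimated step from compound 3 to compound 4 is a step that the limit leaves unreadable from compound 3 to compound 4, meaning that no readable change is expected.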

Compound 4, half-maximal inhibitory concentration: 34400 nM
For compound 4 the middle estimate is 1.7-fold (0.24 log units) above the measured one; the measured number falls inside the stated range.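

In this assay, going by these compounds alone, compound 4 gives 34400 nM, which shows that a change on an aromatic nitrogen of the five-membered aromatic ring with 3 nitrogen can bring a compound of this series to a readable number, something no earlier compound had done: the limit of > 50000 nM in this assay, at which 3 of the 4 values shown sit. The change to 2-chlorophenyl from 3-methylphenyl gives an at least 1.4-fold lower number from compound 3 to compound 4 (0.16 log units; that floor lies within the scatter), and this is only a floor, so the pair shows neither a change beyond the scatter nor its true size. Within the data shown here, the earlier steps cannot be read, which makes this the first step with any size attached, though still a weak one in absolute terms.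

The pair alters the substituent and its place on the phenyl ring together, so it leaves open which of the two matters, and how a plain phenyl, a methoxyphenyl or a pyridyl ring would read in this assay. It also leaves open whether 2-chlorophenyl would give a number on the core of compound 1, which lacks the amine carried by compound 3 and compound 4.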